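The compounds below may be only part of what the source reports. "The series", "measured", "known", "first", "only" and "open" are said of these compounds alone.

Measured compounds:
compound 1, `Cc1ccc(C(=O)Nc2cccc(-c3oc4cc(-c5ccc(F)cc5)ccc4c(=O)c3O)c2)cc1`: 2400 nM
compound 2, `N#Cc1ccc(C(=O)Nc2cccc(-c3oc4cc(-c5ccc(F)cc5)ccc4c(=O)c3O)c2)cc1`: 2660 nM

Both compounds were tested in a functional assay on MCF7 cells (Homo sapiens) for antiproliferative activity, read by CCK-8 assay, with a stated time of 72 h; on this read-out higher numbers stand for weaker inhibition and lower numbers for stronger inhibition. In this assay compound 1 gives 2400 nM and compound 2 gives 2660 nM. Compound 2 has the higher of the two numbers, but its nearest neighbour is compound 1, and the step of a 1.1-fold higher number from compound 1 to compound 2 (0.04 log units; within the scatter) lies within the scatter, so the two compounds cannot be told apart on these data.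

Compound 3, `O=C(Nc1cccc(-c2oc3cc(-c4ccc(F)cc4)ccc3c(=O)c2O)c1)c1ccc([N+](=O)[O-])cc1`, has not yet been measured. It differs from compound 2 in one place: nitro in place of cyano on an aromatic carbon. Among the measured compounds shown here, the one measured step that bears on this change is the exchange at the same place from compound 1 to compound 2, a 1.1-fold higher number from compound 1 to compound 2 (0.04 log units; within the scatter), which replaced a methyl with a cyano and left the number essentially unchanged. A second exchange of a small group at this same place is therefore expected to give no step beyond the scatter, in either direction. The step of a 1.0-fold higher number from compound 2 to compound 3 (0.01 log units; within the scatter) is the estimated outcome. For compound 3 the expected value in this assay is 2700 nM, with a range from 1300 nM to 5600 nM.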

Compound 3, half-maximal inhibitory concentration: 3970 nM
Beside the measured number, compound 3's estimate is 1.5-fold (0.17 log units) below it, and the stated range covers the measured number.
By their numbers in this assay, from the lowest: compounds 1, 2 and 3 (each within the scatter of the next).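

The nitro group gives this position a third measured group, and neither new step in this assay leaves the scatter (in turn, a 1.5-fold higher number from compound 2 to compound 3 (0.17 log units; within the scatter), and a 1.7-fold higher number from compound 1 to compound 3 (0.22 log units; within the scatter)). On these data, methyl, cyano and nitro on this aromatic carbon, para to a large group, cannot be told apart, even though the exchange for nitro brings in oxygen atoms and changes the heavy-atom and hydrogen-bond-acceptor counts. The numbers show only this lack of a clear difference, and no other measurement here offers an explanation for it.

As far as these compounds go, all three groups are small, carry no net charge and have no hydrogen-bond donor, so it remains open whether an amine, a carboxylic acid or a longer chain such as a butyl group at this place would also stay within the scatter or would clearly shift the number. These compounds also share the rest of their structure, so they say nothing about how changes to the 4-fluorophenyl group, the amide or the core would affect activity in these cells.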